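Hydroxy to 3-bromopropyl on the chain of compound 3

The source may hold more compounds than are shown below. What is called first, only, known or untested is meant among the compounds shown, and "the series" means these compounds.

In a functional assay on HL-60 cells (Homo sapiens) for cytotoxicity, read by MTT assay, with a stated time of 24 h (a lower number here means a stronger inhibitor, a higher number a weaker inhibitor), compound 3 `OCCCOc1c(Br)cc(Br)cc1Oc1ccc(Br)cc1Br` gives 29.9 ug/mL, compound 1 `BrCCCOc1c(Br)cc(Br)cc1Oc1ccc(Br)cc1Br` gives 29.9 ug/mL and compound 2 `CN1CCN(CCCCCOc2c(Br)cc(Br)cc2Oc2ccc(Br)cc2Br)CC1` gives 48.3 ug/mL. Compound 3 is level with compound 1 and within the scatter of compound 2. Compound 4 `BrCCCCCCOc1c(Br)cc(Br)cc1Oc1ccc(Br)cc1Br` differs from compound 3 as follows: 3-bromopropyl in place of hydroxy on a saturated chain carbon, three bonds along the chain from an oxygen on an aromatic ring. Cut further out, the same change reads 3-hydroxypropyl to 6-bromohexyl. Three measured steps at this place bear on it: no change at the digits printed from compound 1 to compound 3 (within the scatter), a 1.6-fold higher number from compound 1 to compound 2 (0.21 log units; within the scatter) and a 1.6-fold lower number from compound 2 to compound 3 (0.21 log units; within the scatter). All three lie within the scatter, although none of them is this exact change. No step beyond the scatter is therefore expected in this assay, and the estimated step is a 1.1-fold higher number from compound 3 to compound 4 (0.03 log units; within the scatter). For compound 4 the expected value is 32 ug/mL, with an estimated range of 15 ug/mL to 65 ug/mL.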

Compound 4, half-maximal inhibitory concentration: 37.8 ug/mL
The estimate for compound 4 lay 1.2-fold (0.07 log units) below the measured number; the range from low to high includes it.
By their numbers in this assay, from the lowest: compounds 1, 3, 4 and 2 (each within the scatter of the next).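

In this assay, replacing 3-hydroxypropyl with 6-bromohexyl gives a 1.3-fold higher number from compound 3 to compound 4 (0.10 log units; within the scatter), and the longer bromo chain against the shorter one gives a 1.3-fold higher number from compound 1 to compound 4 (0.10 log units; within the scatter). Against the chain bearing 4-methylpiperazin-1-yl, the result is a 1.3-fold lower number from compound 2 to compound 4 (0.11 log units; within the scatter), so every pair among these four compounds lies within the scatter, and this position has shown no step beyond it. Nothing measured here bears on a reason for these numbers. Going by these compounds, whether a carboxylic acid or a primary amine on this chain, or a chain longer than 6-bromohexyl, would give a step beyond the scatter remains open.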